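The source may hold more compounds than are shown below. What is called first, only, known or untested is meant among the compounds shown, and "the series" means these compounds.

The series is built on a shared core carrying an acetamido group, a pentan-3-yloxy ether and a carboxylic acid, with a benzylamine substituent that is varied. Compound 1 `CCC(CC)O[C@@H]1C=C(C(=O)O)C[C@H](NCc2ccc(SCC(C)C)cc2)[C@H]1NC(C)=O` carries an isobutylsulfanyl group on the benzyl ring. In an ADME assay on cells (Fibroblast, Gallus gallus) for cytotoxicity, read by CCK-8 assay, with a stated time of 48 h (on this read-out lower numbers stand for higher toxicity in this test and higher numbers for lower toxicity in this test), compound 1 gives > 200000 nM, which is a limit of the assay rather than a number. Compound 2 `CCC(CC)O[C@@H]1C=C(C(=O)O)C[C@H](NCc2cccc(SC(C)CC)c2)[C@H]1NC(C)=O` moves a related thioether to another position of the ring. In this assay compound 2 also gives > 200000 nM, again a limit and not a number. Compound 1 therefore stands at the edge of what the assay reports, as shown by the limit of > 200000 nM in this assay, at which 2 of the 2 values shown sit, and nothing in the data ranks it against compound 2.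

Compound 3 `CCC(CC)O[C@@H]1C=C(C(=O)O)C[C@H](NCc2ccc(S(=O)(=O)c3ccccc3)cc2)[C@H]1NC(C)=O` differs from compound 1 in a single place: phenylsulfonyl in place of isobutylsulfanyl on an aromatic carbon. Going by the values given here, no measured step between these compounds exists, so the expected change from compound 1 to compound 3 is none beyond the scatter, estimated as a number no higher from compound 1 to compound 3 (the limit leaves the size open). For compound 3 the expected value in this assay is 200000 nM, with a range from 100000 nM to 400000 nM.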

Compound 3, half-maximal cytotoxic concentration: > 200000 nM
Compound 3: a limit, no number (the forecaster's own chance of this, stated with the estimate: 75%); the middle value lies on the limit itself.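

In this assay compound 3 gives > 200000 nM and this is again a limit, not a number. Going by these compounds alone, no step from compound 1 to compound 3 can be read, because both values are limits: the limit of > 200000 nM in this assay, at which 3 of the 3 values shown sit. The compounds shown leave open whether any of them has a measurable cytotoxic concentration, and whether phenylsulfonyl and isobutylsulfanyl differ on this read-out.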